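Swapping Chloro for Methoxy on the Second Aryl Ring

The source may report more compounds than this note shows. Statements on the series, on what has been measured and on what is new or still open speak of the compounds shown alone.

Three compounds have been measured in an ADME assay on microsomes from liver (Homo sapiens) for metabolic stability, tested at 2.5 uM; on this read-out lower numbers stand for slow clearance and higher numbers for fast clearance:
Compound 1 `O=S(=O)(c1ccc(F)c(Cl)c1)c1cnc2c(F)cccc2c1-c1cccc(Cl)c1` gives 0.18 mL/min.
Compound 2 `COc1ccc(S(=O)(=O)c2cnc3c(F)cccc3c2-c2cccc(Cl)c2)cc1` gives 2.75 mL/min.
Compound 3 `N#Cc1cccc(S(=O)(=O)c2cnc3c(F)cccc3c2-c2cccc(Cl)c2)c1` gives 1.11 mL/min.

Compound 2 stands highest of the three in this assay; its nearest neighbour is reached by the step of a 2.5-fold lower number from compound 2 to compound 3 (0.39 log units; beyond the scatter), and its furthest by the step of a 15-fold higher number from compound 1 to compound 2 (1.18 log units; beyond the scatter). Compound 4 `COc1ccc(S(=O)(=O)c2cnc3c(F)cccc3c2-c2cccc(OC)c2)cc1` differs from compound 2 in one place: methoxy in place of chloro on an aromatic carbon.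

Going by the values given here, every measured step so far alters the ring on the sulfonyl sulfur, not the ring that changes here. The steps of a 6.2-fold higher number from compound 1 to compound 3 (0.79 log units; beyond the scatter) and a 2.5-fold lower number from compound 2 to compound 3 (0.39 log units; beyond the scatter) show that exchanging one aryl group for another can move this read-out well beyond the scatter, but they give no direct guide to a chloro-to-methoxy exchange on the other ring. Among the compounds with values here, no measured pair shares this change, so its direction cannot be read from the data. The number for compound 4 in this assay is therefore expected close to that of compound 2, with a wide range, a 1.1-fold higher number from compound 2 to compound 4 (0.04 log units; within the scatter). Compound 4 is estimated at 3 mL/min, between 1.2 mL/min and 7.5 mL/min.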

Compound 4, intrinsic clearance in a liver preparation (reported as CLH), per the amount of preparation that the assay uses: 2.87 mL/min
The estimate for compound 4 lay 1.0-fold (0.02 log units) above the measured number, within the range that was stated.
By their numbers in this assay, from the lowest: compound 1; then compound 3; then compounds 2 and 4 (each within the scatter of the next).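

In this assay, the only exchange shown on this second aryl ring, 3-chlorophenyl to 3-methoxyphenyl, leaves two numbers that cannot be told apart (a 1.0-fold higher number from compound 2 to compound 4 (0.02 log units; within the scatter)). Going by these compounds alone, all the earlier steps altered the ring on the sulfonyl sulfur and each ended beyond the scatter, whereas chloro and methoxy on this ring read alike, at least with 4-methoxyphenyl on the sulfonyl sulfur. No measurement at hand explains this result.

Going by these compounds, whether the two groups would also read alike with 3-chloro-4-fluorophenyl or 3-cyanophenyl on the sulfonyl sulfur remains open. So does what an amine, a carboxylic acid or a longer chain such as ethoxy would do in the same place on this ring.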